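Removing the sulfonyl from the amine nitrogen of compound 1

This account rests on a few compounds, and the source may have more. Where it says the series, first, only, none or still open, it means among the compounds named here.

The series is followed in a functional assay on 3T3-L1 cells (Mus musculus) for inhibition, with a stated time of 20 min, tested at 20 uM; a lower number here means less inhibition, a higher number more inhibition at the concentration tested (going by the name of the read-out). Compound 1 `Cc1ccc(S(=O)(=O)N(Cc2cccc(F)c2F)Cc2cn(S(=O)(=O)c3ccc(C)cc3)c3ccccc23)cc1` gives -13.9% in this assay. Compound 2 `Cc1ccc(S(=O)(=O)n2c(CN(Cc3cn(Cc4ccc(F)cc4F)nn3)S(C)(=O)=O)c(C)c3ccccc32)cc1` gives -20.8% in this assay. The two numbers lie within the scatter of each other, so compound 1 cannot be set apart from compound 2; both sit around zero, with no inhibition evident at the concentration tested. Within the data shown here, no step between measured compounds is available, so nothing shows how a single change moves the read-out.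

Compound 3 `Cc1ccc(S(=O)(=O)n2cc(CNCc3cccc(F)c3F)c3ccccc32)cc1` is the unmeasured member. It differs from compound 1 in one place: hydrogen in place of (4-methylphenyl)sulfonyl on an amine nitrogen. The remainder of compound 1 is kept. The step of a number 3.9 percentage points higher from compound 1 to compound 3 (within the scatter) is expected to be none beyond the scatter, because compound 1 gives -13.9% and compound 2 gives -20.8%, both near zero. Compound 3 is therefore estimated to give -10% in this assay, with a range from -35% to 15%.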

Compound 3, a percentage reported as inhibition, at one concentration (the size of the read-out at that concentration, not a potency): 46%
Compound 3: middle estimate off by 56 percentage points, on the low side; the measured number lies above the stated range.
By their numbers in this assay, from the lowest: compounds 2 and 1 (each within the scatter of the next); then compound 3.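

The amine nitrogen whose other neighbours are saturated chain carbons is the first position in the series shown to move the read-out: in this assay, hydrogen in place of (4-methylphenyl)sulfonyl gives a number 59.9 percentage points higher from compound 1 to compound 3 (beyond the scatter) with the remainder of compound 1 kept. The earlier numbers gave no sign that the read-out could leave the neighbourhood of zero, whereas compound 3 gives 46%, so inhibition at the concentration tested is reachable on this scaffold, although a reading at one concentration is not a potency. The group that leaves takes a sulfonyl and a six-membered aromatic ring of carbon only with it, and nothing at hand says why the read-out moves.

From the compounds shown here alone, whether a methyl, an acetyl or a methylsulfonyl on this amine nitrogen would keep the read-out of compound 3 remains open, so the step cannot yet be assigned to the sulfonyl, to the aromatic ring or to the presence of the hydrogen itself. Also open, going by these compounds, is whether hydrogen on the amine nitrogen would have a similar effect on the core of compound 2.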